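The source may report more compounds than this note shows. Statements on the series, on what has been measured and on what is new or still open speak of the compounds shown alone.

In a functional assay on SW480 cells (Homo sapiens) for antiproliferative activity, read by MTT assay, with a stated time of 48 h (on this read-out higher numbers stand for weaker inhibition and lower numbers for stronger inhibition), compound 1 (`CC(=O)OC/C1=C/C[C@](C)(CCC=C(C)C)/C=C/[C@@H](OC(=O)C=C(C)C)[C@](C)(O)/C=C/C1=O`) gives 2950 nM and compound 2 (`CC(=O)OC/C1=C/C[C@](C)(CCC=C(C)C)/C=C/[C@@H](OC(=O)C=C(C)C)[C@](C)(OC(C)=O)/C=C/C1=O`) gives 3520 nM, two values within the scatter of each other, while compound 3 (`CO[C@]1(C)/C=C/C(=O)/C(CO)=C\C[C@](C)(CCC=C(C)C)/C=C/[C@H]1OC(=O)C=C(C)C`) gives 15200 nM, a clearly higher number. Compound 1 therefore stands in the lower pair. Compound 4 (`CC(C)=CCC[C@]1(C)/C=C/[C@@H](OC(=O)C=C(C)C)[C@](C)(O)/C=C/C(=O)/C(CCl)=C\C1`) differs from compound 1 at one place: chloro in place of acetoxy on a saturated chain carbon bound to a double-bonded ring carbon. Among the measured compounds shown here, the one measured single-place step, a 1.2-fold higher number from compound 1 to compound 2 (0.08 log units; within the scatter), stays within the scatter, but it concerns a different place, an oxygen on a saturated carbon. Compound 3 differs from compound 1 in more than one place, so it isolates no single change. No measurement covers acetoxymethyl to chloromethyl directly. The expected step is a 1.1-fold lower number from compound 1 to compound 4 (0.02 log units; within the scatter), with no change beyond the scatter anticipated in either direction. For compound 4 the estimated value is 2800 nM, with an expected range from 1000 nM to 8000 nM.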

Compound 4, half-maximal inhibitory concentration: 390 nM
Compound 4: the middle estimate sits 7.2-fold (0.86 log units) above what was measured; the measured number lies below the stated range.
By their numbers in this assay, from the lowest: compound 4; then compounds 1 and 2 (each within the scatter of the next); then compound 3.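

In this assay, chloro in place of acetoxy on a saturated chain carbon bound to a double-bonded ring carbon gives a 7.6-fold lower number from compound 1 to compound 4 (0.88 log units; beyond the scatter), so this position responds clearly to a change of group. Among the compounds shown here, the one earlier single-place step, at a different place, stayed within the scatter. No available evidence accounts for this difference.

Going by these compounds, whether bromo or an amine on this same carbon would give a similar number remains open. So does whether chloro would produce a similar step alongside the other changes carried by compound 2.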